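The compounds below may be only part of what the source reports. "The series", "measured", "known", "first", "only" and "open" are said of these compounds alone.

Measured in a functional assay on MCF7 cells (Homo sapiens) for antiproliferative activity; a higher number here means a weaker inhibitor, a lower number a stronger inhibitor:
- compound 1 `Nc1n[nH]c(N)c1/N=N/c1cccc([N+](=O)[O-])c1`: 65000 nM
- compound 2 `Nc1n[nH]c(N)c1/N=N/c1ccccc1O`: > 100000 nM, a limit
- compound 3 `Nc1n[nH]c(N)c1/N=N/c1cccc(O)c1`: > 100000 nM, a limit

Compound 3 has no exact number, only the limit > 100000 nM. Compound 3 sits at the limit of > 100000 nM in this assay, at which 2 of the 3 values shown sit. Compound 4 `Nc1n[nH]c(N)c1/N=N/c1cccc(C(=O)O)c1` has carboxy in place of hydroxy on an aromatic carbon. Among the measured compounds shown here, the one measured step that changes this same group is an at least 1.5-fold higher number from compound 1 to compound 3 (0.18 log units; that floor lies within the scatter), with hydroxy in place of nitro on an aromatic carbon. That step gives no firm size to carry over, so no change beyond the scatter is expected in this assay, and a further limit is quite possible. The expected step is a number no higher from compound 3 to compound 4 (the limit leaves the size open). For compound 4 the estimated value is 100000 nM, with an expected range of 40000 nM to 250000 nM.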

Compound 4, half-maximal inhibitory concentration: > 100000 nM
Compound 4: a limit, no number; the forecaster's own chance of this, stated with the estimate: 60%; the middle value lies on the limit itself.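

In this assay, carboxy in the same place as hydroxy also leaves compound 4 with a limit rather than an exact number, so the step between compound 3 and compound 4 cannot be read. Replacing nitro with carboxy gives an at least 1.5-fold higher number from compound 1 to compound 4 (0.18 log units; that floor lies within the scatter), so this change too shows no shift beyond the scatter. Compound 1 remains the only one of these with an exact number, and the other values gather at one limit: the limit of > 100000 nM in this assay, at which 3 of the 4 values shown sit.

Going by these compounds, how compound 3 and compound 4 truly compare stays open. So does whether a methoxy group or a chlorine atom in this place would give an exact number.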